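A few compounds are considered here, and "the series" means these few. Any claim that something is new, unique, unknown or untested is made for them only; others in the source may bear on it.

Measured so far:
compound 1, `COc1cc(O)c(C(=O)O)c(C=Cc2ccc3ccccc3c2)c1`: 65000 nM
compound 2, `COc1cc(C=Cc2ccc3ccccc3c2)c(C(=O)O)c(OC)c1`: > 100000 nM
compound 3, `CCN(CC)C(=O)c1c(O)cccc1CCc1ccc2ccccc2c1`: > 100000 nM

In an ADME assay on HEK293 cells (Homo sapiens) for cytotoxicity, read by resazurin assay, with a stated time of 24 h (a higher number here means that more compound is tolerated, a lower number that less compound is tolerated), compound 1 gives 65000 nM. For compound 2 this assay reports only a limit, > 100000 nM. For compound 3 this assay likewise reports only a limit, > 100000 nM. Note (the limit of > 100000 nM in this assay, at which 2 of the 3 values shown sit).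

The change from compound 1 to compound 2 is methyl in place of hydrogen on an oxygen on an aromatic ring. It made an at least 1.5-fold higher number from compound 1 to compound 2 (0.18 log units; that floor lies within the scatter).

Compound 4, `CCN(CC)C(=O)c1c(CCc2ccc3ccccc3c2)cccc1OC`, is not yet measured in this assay. It differs from compound 3 by methyl in place of hydrogen on an oxygen on an aromatic ring. The place is described in the same words as for the change from compound 1 to compound 2, so this is the same change made on another core; how the core of compound 1 and the core of compound 3 differ is not broken down here.

For compound 4 the expected step is a step that the limit leaves unreadable from compound 3 to compound 4, a step that is estimated to stay within the scatter. This rests on the earlier step, an at least 1.5-fold higher number from compound 1 to compound 2 (0.18 log units; that floor lies within the scatter), whose floor lies within the scatter. It also rests on compound 3, for which this assay reports only a limit, > 100000 nM. Compound 4 is expected in this assay at 150000 nM, estimated between 60000 nM and 400000 nM, most likely again as a limit rather than a number.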

Compound 4, half-maximal cytotoxic concentration: 85700 nM
For compound 4 the middle estimate is 1.8-fold (0.24 log units) above the measured one; the range from low to high includes it.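

Hydroxy to methoxy on the core of compound 3 gives in this assay an at least 1.1-fold lower number from compound 3 to compound 4 (0.06 log units; that floor lies within the scatter). For compound 3, this assay reports only a limit, > 100000 nM, so this step has a floor and no true size, and the same holds for the earlier step on the core of compound 1. The pair of steps therefore shows that the change has been made on two cores without either step being read beyond the scatter, but it does not show that the change carries over from one core to the other with the same size or direction: the same change on two cores in this assay, an at least 1.5-fold higher number (0.18 log units; that floor lies within the scatter) from compound 1 to compound 2 and an at least 1.1-fold lower number (0.06 log units; that floor lies within the scatter) from compound 3 to compound 4; the limit leaves it open whether they differ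

Still open, as far as these compounds go, is how this assay responds to a larger group on that oxygen, such as ethyl or a longer chain, or to an amine carried on a chain there. Also open, from the compounds shown here alone, is whether any such group on either core would give a step that can be read on both sides, with numbers in place of limits.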